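The source may hold more compounds than are shown below. What is called first, only, known or untested is meant among the compounds shown, and "the series" means these compounds.

Measured in a functional assay on HepG2 cells (Homo sapiens) for cytotoxicity, read by MTT assay, with a stated time of 48 h; on this read-out higher numbers stand for weaker inhibition and lower numbers for stronger inhibition:
Compound 1 `O=C1/C(=C\c2ccccc2)S/C(=N/c2ccccc2)N1Cc1ccncc1`: 25200 nM
Compound 2 `COc1ccc(/C=C2/S/C(=N/c3ccccc3)N(Cc3ccncc3)C2=O)cc1`: 19100 nM
Compound 3 `O=C1/C(=C\c2ccc([N+](=O)[O-])cc2)S/C(=N/c2ccccc2)N1Cc1ccncc1`: 18900 nM

Compound 3 cannot be told apart from the other two, as every gap among them lies within the scatter. Compound 4 `O=C1/C(=C\c2ccc(O)c(O)c2)S/C(=N/c2ccccc2)N1Cc1ccncc1` carries one change: 3,4-dihydroxyphenyl in place of 4-nitrophenyl on a double-bonded chain carbon bound to a double-bonded ring carbon. Among the compounds with values here, three measured steps bear on it, all changes on the same aromatic ring. Methoxy in place of hydrogen gave a 1.3-fold lower number from compound 1 to compound 2 (0.12 log units; within the scatter), nitro in place of hydrogen gave a 1.3-fold lower number from compound 1 to compound 3 (0.12 log units; within the scatter), and nitro in place of methoxy gave a 1.0-fold lower number from compound 2 to compound 3 (0.00 log units; within the scatter). Within the data shown here, no measured compound carries 3,4-dihydroxyphenyl, so this is an extrapolation and the range is kept wide. No step beyond the scatter is expected, and the estimate is a 1.1-fold higher number from compound 3 to compound 4 (0.02 log units; within the scatter). For compound 4 the expected value is 20000 nM, with an estimated range from 9000 nM to 40000 nM.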

Compound 4, half-maximal inhibitory concentration: 16200 nM
The estimate for compound 4 lay 1.2-fold (0.09 log units) above the measured number, within the range that was stated.
By their numbers in this assay, from the lowest: compounds 4, 3, 2 and 1 (each within the scatter of the next).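

3,4-Dihydroxyphenyl brings hydrogen-bond donors that the earlier groups at this position lack, yet in this assay every step to it stays within the scatter (a 1.2-fold lower number from compound 3 to compound 4 (0.07 log units; within the scatter)) and (a 1.2-fold lower number from compound 2 to compound 4 (0.07 log units; within the scatter)) and (a 1.6-fold lower number from compound 1 to compound 4 (0.19 log units; within the scatter)). Within the data shown here, this position now holds phenyl, 4-methoxyphenyl, 4-nitrophenyl and 3,4-dihydroxyphenyl with no step that stands out from the scatter. No supporting measurement is available to explain this result. Still open, on these data alone, is whether an amine or a carboxylic acid on this ring, or a longer chain in place of the ring, would move the number beyond the scatter.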